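The compounds below may be only part of what the source reports. "The series", "measured", "known", "first", "only" and "open" are said of these compounds alone.

Measured in a functional assay on HCT-116 cells (Homo sapiens) for antiproliferative activity, read by sulforhodamine B assay; a higher number here means a weaker inhibitor, a lower number a stronger inhibitor:
- compound 1 `O=C1NC(=O)c2ccc(I)cc2/C1=C/Nc1ccc(CN2CCCCC2)cc1`: 2700 nM
- compound 2 `O=C1NC(=O)c2ccc(-n3cccc3)cc2/C1=C/Nc1ccc(CN2CCCCC2)cc1`: 2700 nM
- compound 3 `O=C1NC(=O)c2ccc(-c3ccc(F)cc3)cc2/C1=C/Nc1ccc(CN2CCCCC2)cc1`: 1000 nM

Compound 1 stands level with compound 2, and together they hold the highest of the three numbers. Compound 3 is the most potent of the set, with a 2.7-fold lower number from compound 1 to compound 3 (0.43 log units; beyond the scatter) and a 2.7-fold lower number from compound 2 to compound 3 (0.43 log units; beyond the scatter). The remaining comparison is no change at the digits printed from compound 1 to compound 2 (within the scatter).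

Compound 4 `CN1CC2CC1CN2c1ccc(N/C=C2\C(=O)NC(=O)c3ccc(I)cc32)cc1` keeps the iodo group of compound 1 and changes the other end of the molecule: a group of 8 heavy atoms (6 carbon, 2 nitrogen; 2 five-membered non-aromatic rings with 1 hetero atom each) in place of a group of 7 heavy atoms (6 carbon, 1 nitrogen; one six-membered non-aromatic ring with 1 hetero atom), on an aromatic carbon. The (piperidin-1-yl)methyl group is replaced there, on an aromatic carbon of a six-membered aromatic ring of carbon only, para to a large group.

Among the measured compounds shown here, none of the measured steps touches this place. For the measured compounds named here, all three replace the iodo group or its successors, so they show only that single changes on this core have so far been modest or within the scatter in this assay. They give no direction for the new group, so no step beyond the scatter is expected, though with wide uncertainty. The expected change is a 1.2-fold lower number from compound 1 to compound 4 (0.09 log units; within the scatter). For compound 4 the estimated value is 2200 nM, with an expected range of 600 nM to 7000 nM.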

Compound 4, half-maximal inhibitory concentration: 1900 nM
Estimate against measurement, compound 4: 1.2-fold (0.06 log units) above; low and high end bracket the measured number.
By their numbers in this assay, from the lowest: compounds 3, 4, 1 and 2 (each within the scatter of the next, the first and the last beyond it).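

Among the compounds shown here, compound 4 gives the first reading at the place on an aromatic carbon of a six-membered aromatic ring of carbon only, para to a large group, where compounds 1, 2 and 3 all carry (piperidin-1-yl)methyl. In this assay, with the iodo group kept, putting the group of 8 heavy atoms with 2 five-membered non-aromatic rings at this place gives a 1.4-fold lower number from compound 1 to compound 4 (0.15 log units; within the scatter), so this exchange, from 1 hydrogen-bond acceptor to 2 in the group, brings no step beyond the scatter. Nothing available here bears on the reason for this result.

The compounds shown leave open whether the same exchange would behave alike with 4-fluorophenyl or 1H-pyrrol-1-yl in place of the iodo group, since this one step stands on the iodo compounds alone. They also leave open how this place would respond to a morpholine ring, an open-chain amine such as dimethylaminomethyl, or a carboxylic acid, and whether any group there could produce a step beyond the scatter.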